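This account rests on a few compounds, and the source may have more. Where it says the series, first, only, none or still open, it means among the compounds named here.

Compound 1, `CC(C(=O)N1CCN(c2ccc(Cl)cc2)CC1)N1C(=O)CCC1=O`: 0%
Compound 2, `CCC(C(=O)N1CCN(c2ccccc2F)CC1)N1C(=O)CCC1=O`: 50%

Of the compounds shown here, two have been tested in a functional assay on the whole organism (strain Swiss) with Mus musculus as the target, in the maximal electroshock model, with a stated time of 1 h, at a dose of 300 mg/kg by the intraperitoneal route; on this read-out higher numbers stand for a stronger effect at the one dose given and lower numbers for a weaker effect. Compound 1 gives 0%, while compound 2 gives 50%, the higher of the two numbers, with a gap to compound 1 that lies beyond the usual scatter. These two compounds differ in more than one place, so no single structural change can be tied to that gap; only the two values themselves are known.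

Compound 3, `CCC(C(=O)N1CCN(c2ccc(Cl)cc2)CC1)N1C(=O)CCC1=O`, has not yet been measured in this assay. It differs from compound 2 in one place: 4-chlorophenyl in place of 2-fluorophenyl on an amine nitrogen in a ring. For the measured compounds named here, the 4-chlorophenyl group is the one carried by compound 1, whose value is 0%, so some loss of effect is expected. The step from compound 2 to compound 3 is expected to be a moderate fall, a number 25 percentage points lower from compound 2 to compound 3 (beyond the scatter), beyond the scatter. Compound 3 is estimated at 25%, with a range from 0% to 60%.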

Compound 3, a percentage reported as activity, at one dose (the size of the read-out at that dose, not a potency): 25%
The estimate for compound 3 equals the measured number at the digits printed; the measured number falls inside the stated range.
By their numbers in this assay, from the lowest: compound 1; then compound 3; then compound 2.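

In this assay each new step isolates a single change, which the first two compounds could not do. Placing 4-chlorophenyl where 2-fluorophenyl stood on the amine nitrogen in the ring gives a number 25 percentage points lower from compound 2 to compound 3 (beyond the scatter) as the step, and methyl in place of hydrogen on the saturated chain carbon, with 4-chlorophenyl kept, gives a number 25 percentage points higher from compound 1 to compound 3 (beyond the scatter) as the step, so the read-out responds to a change at either place. No measurement is available to explain either step.

The aryl swap alters both the halogen and its ring position at once, so 2-chlorophenyl or 4-fluorophenyl would be needed to tell those two apart. On these data alone, whether a longer chain, such as propyl, would carry the rise further also stays open.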